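This account rests on a few compounds, and the source may have more. Where it says the series, first, only, none or still open, it means among the compounds named here.

Measured compounds in the series:
compound 1, `C[C@H](NS(=O)(=O)c1cccc(C(=O)NO)c1)C(=O)Nc1ccccc1` — 24200 nM
compound 2, `CC(C)[C@H](NS(=O)(=O)c1cccc(C(=O)NO)c1)C(=O)Nc1ccccc1` — 33900 nM
compound 3, `O=C(NO)c1cccc(S(=O)(=O)N[C@H](C(=O)NCc2ccccc2)c2ccccc2)c1` — 9200 nM

All three were tested in an assay on isolated protein for inhibition of histone deacetylase 8 (Homo sapiens), read by fluorescence, with stated times of 5 min and 30 min; on this read-out higher numbers stand for weaker inhibition and lower numbers for stronger inhibition. Compound 2 carries the highest number of the three; its nearest neighbour is compound 1, and the two values sit within the usual scatter of each other, so no ordering between compound 1 and compound 2 is claimed. The value of compound 3 lies clearly lower than that of compound 2, and that gap is beyond the scatter.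

The next compound, compound 4, `O=C(CNS(=O)(=O)c1cccc(C(=O)NO)c1)Nc1ccccc1`, is not yet measured in this assay. Compared with compound 2 the change is hydrogen in place of isopropyl on a saturated chain carbon bound to a carbonyl carbon and a sulfonamide nitrogen.

For the measured compounds named here, only one measured step bears on this position: a 1.4-fold higher number from compound 1 to compound 2 (0.15 log units; within the scatter). That step, which enlarged the group at the same place, stayed within the scatter. Removing the group altogether is therefore expected to move the number little, if at all; if anything the direction should be toward a lower number, reversing the small drift seen from compound 1 to compound 2, but nothing beyond the scatter is expected.

Compound 4 is accordingly estimated at 24000 nM, with a range of 10000 nM to 55000 nM, a step of a 1.4-fold lower number from compound 2 to compound 4 (0.15 log units; within the scatter) that is expected to stay within the scatter.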

Compound 4, half-maximal inhibitory concentration: 3500 nM
Estimate against measurement, compound 4: 6.9-fold (0.84 log units) above, and the stated range ends above it.
By their numbers in this assay, from the lowest: compound 4; then compound 3; then compounds 1 and 2 (each within the scatter of the next).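

In this assay, hydrogen in place of isopropyl on a saturated chain carbon bound to a carbonyl carbon and a sulfonamide nitrogen gives a 9.7-fold lower number from compound 2 to compound 4 (0.99 log units; beyond the scatter) and the matching replacement of methyl gives a 6.9-fold lower number from compound 1 to compound 4 (0.84 log units; beyond the scatter) so this position does respond to change, and both steps lie beyond the scatter. The earlier step, a 1.4-fold higher number from compound 1 to compound 2 (0.15 log units; within the scatter) had not shown this, since it left methyl and isopropyl unseparated; among these three compounds, the difference appears only between hydrogen and either carbon group, so the two carbon groups give no graded trend. No measured information available here accounts for the difference between hydrogen and these carbon groups.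

Going by these compounds, it remains open whether a group such as ethyl, an aminomethyl chain or a carboxylic acid on this carbon would stay with methyl and isopropyl or come closer to hydrogen. On these data alone, it is also open whether hydrogen at this place would have the same effect alongside a different group on the amide nitrogen, such as benzyl, since every step read here keeps the anilide of compounds 1, 2 and 4.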